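The source may report more compounds than this note shows. Statements on the series, on what has been measured and on what is new or still open speak of the compounds shown alone.

Compound 1 `CC#CCn1c(N2CCC[C@@H](N)C2)cc(=O)n(Cc2cccc(F)c2C(=O)O)c1=O` gives in an ADME assay on Sf9 cells for inhibition of Dipeptidyl peptidase 9 (Homo sapiens), read by fluorescence, with stated times of 60 s and 20 min (a lower number here means a stronger inhibitor, a higher number a weaker inhibitor), only a limit, > 100000 nM.
Compound 2 `CC#CCn1c(N2CCC[C@@H](N)C2)cc(=O)n(Cc2cc(Br)ccc2C(=O)O)c1=O` gives in this assay only a limit, > 100000 nM.
Compound 3 `CC#CCn1c(N2CCC[C@@H](N)C2)cc(=O)n(Cc2cccc(F)c2C(=O)OC)c1=O` gives in this assay only a limit, > 100000 nM.

Going by the values given here, all three measured compounds sit at the limit of > 100000 nM in this assay, at which 3 of the 3 values shown sit, so none of the measured steps can be sized. Compound 1 and compound 3 differ by methyl in place of hydrogen on an oxygen next to a carbonyl group, and the step between them reads a step that the two limits leave unreadable from compound 1 to compound 3. Compound 1 and compound 2 differ in their cores by 5-bromo-2-carboxyphenyl in place of 2-carboxy-3-fluorophenyl on a saturated chain carbon bound to an aromatic nitrogen, and that step reads a step that the two limits leave unreadable from compound 1 to compound 2.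

Compound 4 `CC#CCn1c(N2CCC[C@@H](N)C2)cc(=O)n(Cc2cc(Br)ccc2C(=O)OC)c1=O` has not yet been measured in this assay. It stands to compound 2 as compound 3 stands to compound 1: it differs from compound 2 by methyl in place of hydrogen on an oxygen next to a carbonyl group, the same change, at the same place, that carries compound 1 to compound 3. Since compound 2 sits at the limit of > 100000 nM in this assay, at which 3 of the 3 values shown sit, and the corresponding change on compound 1 left compound 3 at the same limit, the step from compound 2 to compound 4 is expected to be a step that the limit leaves unreadable from compound 2 to compound 4. Compound 4 is therefore estimated to give 200000 nM, most likely reported again only as a limit, within a range of 60000 nM to 700000 nM.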

Compound 4, half-maximal inhibitory concentration: > 100000 nM
Compound 4: a limit, no number; the forecaster's own chance of this, stated with the estimate: 90%; the middle value is on the limit's open side.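

No new step can be read: compound 2 and compound 4 both give only a limit in this assay, so the change from carboxy to methoxycarbonyl between them has no readable size. The compounds shown leave open what any of the four would give as an actual number in this assay, and whether that change has any effect on inhibition.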